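The source may hold more compounds than are shown below. What is called first, only, known or untested is meant among the compounds shown, and "the series" means these compounds.

For the measured compounds named here, in a functional assay on T29Kt1 cells (Homo sapiens) for cytotoxicity, read by sulforhodamine B assay, with a stated time of 3 days (on this read-out higher numbers stand for weaker inhibition and lower numbers for stronger inhibition), compound 1 `OCc1cn(Cc2ccc(Cl)cc2)c2ccccc12` gives 79 nM, the lowest number so far. Compound 2 `OCc1cn(Cc2ccc(Cl)c(Cl)c2)c2ccccc12` gives 310 nM and compound 3 `OCc1cn(Cc2ccc(Cl)cc2)c2cc(F)ccc12` gives 1000 nM. Compound 4 `O=C(NC1CCCCC1)OCc1cn(Cc2ccc(Cl)cc2)c2ccccc12` is still unmeasured. It differs from compound 1 by cyclohexylcarbamoyl in place of hydrogen on an oxygen on a saturated carbon, with cyclohexylcarbamoyl in place of hydrogen on an oxygen on a saturated carbon. The two measured steps are a 3.9-fold higher number from compound 1 to compound 2 (0.59 log units; beyond the scatter), a modest one with chloro in place of hydrogen on an aromatic carbon, and a 13-fold higher number from compound 1 to compound 3 (1.10 log units; beyond the scatter), a large one with fluoro in place of hydrogen on an aromatic carbon. Neither changes that oxygen, so they offer only loose guidance, but both raised the number. A modest upward move is therefore expected, and the estimated step is a 3.8-fold higher number from compound 1 to compound 4 (0.58 log units; beyond the scatter). Compound 4 is expected at 300 nM, with an estimated range from 60 nM to 1500 nM.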

Compound 4, half-maximal inhibitory concentration: 200 nM
The estimate for compound 4 lay 1.5-fold (0.18 log units) above the measured number; measured number inside the range.
By their numbers in this assay, from the lowest: compound 1; then compounds 4 and 2 (each within the scatter of the next); then compound 3.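

This is the first change shown on the oxygen itself rather than on an aromatic carbon. In this assay, adding cyclohexylcarbamoyl to that oxygen gives a 2.5-fold higher number from compound 1 to compound 4 (0.40 log units; beyond the scatter), so replacing the hydrogen costs some activity, yet a group of this size does not abolish it. Nothing available explains this step.

The compounds shown leave open whether the loss follows from the cyclohexyl ring or from the carbamoyl link. A methylcarbamoyl or phenylcarbamoyl group, or an acetyl group, on the same oxygen would help separate the two.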